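Replacing the ethoxycarbonyl group of compound 1

The source may report more compounds than this note shows. Statements on the series, on what has been measured and on what is new or still open speak of the compounds shown alone.

Measured in a functional assay on SK-BR-3 cells (Homo sapiens) for cytotoxicity, read by MTT assay, with a stated time of 72 h; a lower number here means that less compound is needed, a higher number that more compound is needed for the effect:
- compound 1 `CCOC(=O)c1c(C)coc1-c1ccc2c(CC)cccc2c1OC` gives 2.5 ug/mL
- compound 2 `CCc1cccc2c(OC)c(-c3occ(C)c3C(=O)On3nnc4ccccc43)ccc12` gives > 10 ug/mL as a limit
- compound 3 `CCOc1c(-c2occ(C)c2CO)ccc2c(CC)cccc12` gives 8.8 ug/mL

Of the two numbers, compound 1 holds the lower, and compound 3 lies higher, beyond the scatter. Next is compound 4 `CCc1cccc2c(OC)c(-c3occ(C)c3COC)ccc12`, with the change (methoxymethyl in place of ethoxycarbonyl on an aromatic carbon). Among the measured compounds shown here, the one measured step at this ester, an at least 4.0-fold higher number from compound 1 to compound 2 (0.60 log units; beyond the scatter), falls on the oxygen next to the carbonyl group and lies beyond the scatter, but it is a different change and gives only a direction. On that step and on compound 3 at 8.8 ug/mL, a modest rise in this assay is expected, estimated as a 2.4-fold higher number from compound 1 to compound 4 (0.38 log units; beyond the scatter). For compound 4 the estimate is 6 ug/mL, with an expected range of 2.2 ug/mL to 13 ug/mL.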

Compound 4, concentration for half-maximal effect: > 10 ug/mL
Compound 4: only a limit was reported (the forecaster's own chance of this, stated with the estimate: 20%); at least 1.6-fold (0.22 log units) between middle value and limit.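

In this assay, methoxymethyl in place of ethoxycarbonyl on this aromatic carbon gives an at least 4.0-fold higher number from compound 1 to compound 4 (0.60 log units; beyond the scatter), so the low number of compound 1 is lost not only with the larger ester of compound 2 but also when the ester itself is replaced. Compound 4 gives > 10 ug/mL, which is a limit. The step is therefore bounded on one side only, and compound 4 cannot be ordered against compound 2: the limit of > 10 ug/mL in this assay, at which 2 of the 4 values shown sit.

As far as these compounds go, whether a carboxylic acid or an amide on this aromatic carbon would stay close to compound 1 remains open.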